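Methoxymethoxy to methoxy on the shared core

A few compounds are considered here, and "the series" means these few. Any claim that something is new, unique, unknown or untested is made for them only; others in the source may bear on it.

Measured in a functional assay on REH cells (Homo sapiens) for cytotoxicity, read by resazurin assay, with a stated time of 72 h (a higher number here means a weaker inhibitor, a lower number a stronger inhibitor), so far:
- compound 1 `COCOc1cc(OC)cc(OC)c1C(=O)/C=C/c1ccccc1` gives 19400 nM as a number
- compound 2 `COCOc1cc(OCOC)c(C(=O)/C=C/c2ccccc2)c(OCOC)c1` gives > 20000 nM as a limit only

Compound 2 stands at the limit of the assay and has no number. Compound 3 `COCOc1cc(OC)c(C(=O)/C=C/c2ccccc2)c(OCOC)c1` differs from compound 2 by hydrogen in place of methoxy on a saturated chain carbon bound to an oxygen on an aromatic ring, read one bond further out as methoxymethoxy to methoxy. Among the compounds with values here, no measured step in this assay covers this change, and compound 1 at 19400 nM is the only number available. No step beyond the scatter is expected. The estimated move an at least 1.1-fold lower number from compound 2 to compound 3 (0.04 log units; that floor lies within the scatter) is expected to stay small. For compound 3 the estimated value is 18000 nM with an expected range from 9000 nM to 30000 nM in this assay.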

Compound 3, half-maximal inhibitory concentration: 9200 nM
Compound 3: the middle estimate sits 2.0-fold (0.29 log units) above what was measured; measured number inside the range.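

Methoxymethoxy to methoxy on the shared core is the first change here to give a step beyond the scatter, an at least 2.1-fold lower number from compound 2 to compound 3 (0.33 log units; beyond the scatter); that step is a floor, not a size: the limit of > 20000 nM in this assay, at which 1 of the 3 values shown sits.

The reverse exchange, methoxy to methoxymethoxy, also lowers the number, a 2.1-fold lower number from compound 1 to compound 3 (0.32 log units; beyond the scatter). The exchange therefore has no single direction across these compounds, and compound 3, with its mix of the two groups, gives the lowest number of the three.

Open, from the compounds shown here alone, is whether a hydroxy group or a longer chain such as ethoxy on these oxygens would lower the number further. Going by these compounds, the size of the step from compound 2 also remains open.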